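The compounds below may be only part of what the source reports. "The series", "measured", "known", "first", "only" and "open" are said of these compounds alone.

Measured so far:
compound 1 `CCc1ccc2oc(CSc3nnc(CNc4ccccc4)n3CC)nc2c1` — 1800 nM
compound 2 `CCn1c(CNc2ccccc2)nnc1SCC(=O)Nc1ccccc1` — > 10000 nM

Among the compounds with values here, in an assay on isolated protein for inhibition of long-chain fatty acid transport protein 1 (Mus musculus) (on this read-out lower numbers stand for stronger inhibition and higher numbers for weaker inhibition), compound 1 gives 1800 nM, the only true number in this small set. Compound 2 reaches only the assay limit, > 10000 nM; this is the limit of > 10000 nM in this assay, at which 1 of the 2 values shown sits, and not a number. Compound 3 `CCn1c(CNc2ccccc2)nnc1SCc1nc2cc(C(=O)C(C)C)ccc2o1` keeps the core of compound 1 and differs by isopropylcarbonyl in place of ethyl on an aromatic carbon, in words: isopropylcarbonyl in place of ethyl on an aromatic carbon. Within the data shown here, no measured pair shows this change, so in this assay the step is expected to stay within the usual scatter or barely beyond it, in no firm direction. Compound 3 is estimated at 1500 nM, between 500 nM and 5000 nM, a step of a 1.2-fold lower number from compound 1 to compound 3 (0.08 log units; within the scatter).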

Compound 3, half-maximal inhibitory concentration: 520 nM
The estimate for compound 3 lay 2.9-fold (0.46 log units) above the measured number; the range from low to high includes it.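

In this assay, within the data shown here, the aromatic carbon that holds ethyl in compound 1 also accepts the larger isopropylcarbonyl, and this change gives a 3.5-fold lower number from compound 1 to compound 3 (0.54 log units; beyond the scatter) as the first readable step at this position. The position is therefore not limited to a small alkyl group, and a carbonyl-bearing group here is compatible with a lower number. No data shown here explain the step.

Whether the carbonyl or the branched carbons account for the step remains open. As far as these compounds go, the outcome with an isobutyl chain or a carboxylic acid on this carbon also remains open.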